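Moving the trifluoromethyl group on a benzyl arm

This account rests on a few compounds, and the source may have more. Where it says the series, first, only, none or still open, it means among the compounds named here.

In a functional assay on T98G cells (Homo sapiens) for cytotoxicity, read by MTT assay (on this read-out higher numbers stand for weaker inhibition and lower numbers for stronger inhibition), compound 1 `Oc1ccc(CN(Cc2ccccc2)Cc2ccc(O)c3ncccc23)c2cccnc12` gives 249 nM and compound 2 `Oc1ccc(CN(Cc2ccccc2C(F)(F)F)Cc2ccc(O)c3ncccc23)c2cccnc12` gives 210 nM, so compound 2 stands level with compound 1 within the scatter. Compound 3 `Oc1ccc(CN(Cc2cccc(C(F)(F)F)c2)Cc2ccc(O)c3ncccc23)c2cccnc12` has not yet been measured. It has the same atoms as compound 2, joined differently: 3-(trifluoromethyl)phenyl in place of 2-(trifluoromethyl)phenyl on a saturated chain carbon bound to an amine nitrogen. In words, 3-(trifluoromethyl)phenyl replaces 2-(trifluoromethyl)phenyl on a saturated chain carbon bound to an amine nitrogen. Among the measured compounds shown here, only one measured step bears on this change, the introduction of the trifluoromethyl group, which gave a 1.2-fold lower number from compound 1 to compound 2 (0.07 log units; within the scatter). That step does not test where the group sits, so it is only indirect evidence. Since it stayed within the scatter, no step beyond the scatter is expected in this assay, and neither direction is favoured. The expected step is a 1.0-fold higher number from compound 2 to compound 3 (0.02 log units; within the scatter). For compound 3 the estimated value is 220 nM, with an expected range from 100 nM to 480 nM.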

Compound 3, half-maximal inhibitory concentration: 57 nM
Compound 3: the middle estimate sits 3.9-fold (0.59 log units) above what was measured; measured number outside the range, below it.
By their numbers in this assay, from the lowest: compound 3; then compounds 2 and 1 (each within the scatter of the next).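

In this assay, the move from 2-(trifluoromethyl)benzyl to 3-(trifluoromethyl)benzyl gives a 3.7-fold lower number from compound 2 to compound 3 (0.57 log units; beyond the scatter) with no change in atoms, so the place of attachment on the benzyl arm alone separates these two compounds. The earlier pair could not show this, and adding trifluoromethyl is now seen to depend on where it sits: the 3-(trifluoromethyl)phenyl arm gives a 4.4-fold lower number from compound 1 to compound 3 (0.64 log units; beyond the scatter) against the plain benzyl arm, while the step to the 2-(trifluoromethyl)phenyl arm stayed within the scatter. Nothing at hand accounts for the difference between the two placements.

The compounds shown leave open whether this place favours trifluoromethyl in particular or would give a similar step with a chlorine atom, a methoxy group or a nitrile. They also leave open whether the other benzyl-bearing parts of the shared core tolerate such changes.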